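Para-substituent swaps on the benzamide arm of the series

The compounds below may be only part of what the source reports. "The series", "measured", "known", "first", "only" and "open" are said of these compounds alone.

Compound 1 `CN1[C@@H]2c3[nH]c4ccccc4c3C[C@H]1[C@H](C#N)N1[C@@H](CNC(=O)c3ccc(Cl)cc3)c3[nH]c4ccccc4c3C[C@@H]21` — a functional assay on HepG2 cells (Homo sapiens) for cytotoxicity, read by MTT assay, with a stated time of 72 h (a lower number here means a stronger inhibitor, a higher number a weaker inhibitor), 350 nM
Compound 2 `COc1ccc(C(=O)NC[C@H]2c3[nH]c4ccccc4c3C[C@H]3[C@H]4c5[nH]c6ccccc6c5C[C@@H]([C@H](C#N)N23)N4C)cc1` — this assay 310 nM

Compound 2 stands at the lower of the two numbers, with compound 1 the nearest at a 1.1-fold lower number from compound 1 to compound 2 (0.05 log units; within the scatter). Compound 3 `CN1[C@@H]2c3[nH]c4ccccc4c3C[C@H]1[C@H](C#N)N1[C@@H](CNC(=O)c3ccc(F)cc3)c3[nH]c4ccccc4c3C[C@@H]21` carries fluoro in place of methoxy on an aromatic carbon. For the measured compounds named here, only that one step bears on the question, and it stayed within the scatter, so the para group has so far made no difference that can be read. For compound 3 a step of a 1.1-fold higher number from compound 2 to compound 3 (0.03 log units; within the scatter) is expected, none beyond the scatter. Compound 3 is therefore estimated at 330 nM, with a range from 160 nM to 700 nM.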

Compound 3, half-maximal inhibitory concentration: 210 nM
Estimate against measurement, compound 3: 1.6-fold (0.20 log units) above, and the stated range covers the measured number.
By their numbers in this assay, from the lowest: compounds 3, 2 and 1 (each within the scatter of the next).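

With fluoro now alongside chloro and methoxy at this aromatic carbon in this assay, a third group leaves the number unchanged within the scatter, both for fluoro in place of methoxy (a 1.5-fold lower number from compound 2 to compound 3 (0.17 log units; within the scatter)) and for fluoro in place of chloro (a 1.7-fold lower number from compound 1 to compound 3 (0.22 log units; within the scatter)). No ordering of compounds 1, 2 and 3 can be drawn from these steps. No measurement here bears on why these groups read alike.

Still open, from the compounds shown here alone, is whether an amine, a carboxylic acid or a longer chain at this carbon would give a step beyond the scatter. Going by these compounds, whether the same holds on other carbons of this ring also remains open.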